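Naphthalenyl in place of chlorophenyl on the triazine-linked amide series

The source may report more compounds than this note shows. Statements on the series, on what has been measured and on what is new or still open speak of the compounds shown alone.

Three compounds of this series have been run in an ADME assay on MT4 cells (Homo sapiens) for cytotoxicity, read by MTT assay; on this read-out higher numbers stand for lower toxicity in this test and lower numbers for higher toxicity in this test. Compound 1 `O=C(CSc1nncnc1-c1ccccc1Cl)N1CCc2ccccc2C1` is read only as a limit, >= 38000 nM, not a number; on these figures compound 1 therefore stands at a limit rather than at a measured point, as noted in the limit of >= 38000 nM in this assay, at which 1 of the 3 values shown sits. Compound 2 `COC(=O)c1ccc(NC(=O)CSc2nncnc2-c2ccccc2Cl)c(Br)c1` gives 59000 nM in this assay, and compound 3 `O=C(CSc1nncnc1-c1ccccc1Cl)Nc1ccccn1` gives 172000 nM.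

Compound 4 `O=C(CSc1nncnc1-c1cccc2ccccc12)N1CCc2ccccc2C1` has not yet been measured. The change from compound 1 is naphthalen-1-yl in place of 2-chlorophenyl on an aromatic carbon. Going by the values given here, no measured step between these compounds exists, so the expected step that the limit leaves unreadable from compound 1 to compound 4 is taken to lie within the scatter, with no direction set. Compound 4 is thus expected to give about 40000 nM, likely between 15000 nM and 120000 nM.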

Compound 4, half-maximal cytotoxic concentration: 13000 nM
Compound 4: the middle estimate sits 3.1-fold (0.49 log units) above what was measured; the whole stated range lies above it.
By their numbers in this assay, from the lowest: compound 4; then compound 2; then compound 3.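

In this assay, naphthalen-1-yl in place of 2-chlorophenyl on this aromatic carbon gives an at least 2.9-fold lower number from compound 1 to compound 4 (0.46 log units; beyond the scatter), so a change at this position can move the read-out towards higher toxicity in this test. Compound 1 is read only as a limit, >= 38000 nM, not a number, so the true size of the step stays unfixed: the limit of >= 38000 nM in this assay, at which 1 of the 4 values shown sits.

Open, as far as these compounds go, is whether a plain phenyl or a 2-methylphenyl at this carbon would separate the loss of chlorine from the gain of the second ring. Also open, from the compounds shown here alone, is whether the same change would carry over to the amides of compound 2 and compound 3.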